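Swapping in naphthalen-1-yl at the limit of the assay

The source may hold more compounds than are shown below. What is called first, only, known or untested is meant among the compounds shown, and "the series" means these compounds.

In an ADME assay on cells (Astrocyte, Homo sapiens) for cytotoxicity, read by WST assay, with a stated time of 72 h (on this read-out higher numbers stand for weaker inhibition and lower numbers for stronger inhibition), compound 1 `O=C(Nc1cccc(Cl)c1)Nc1cc2ncncc2cc1OCc1ccccc1Cl` gives > 10000 nM, which is a limit and not a number. Compound 3 `O=C(Nc1cccc(Cl)c1)Nc1cc2ncncc2cc1OCc1cccc(Cl)c1` likewise gives only a limit, > 10000 nM. For the measured compounds named here, the one true number belongs to compound 2 `O=C(Nc1ccc(Cl)c(Cl)c1)Nc1cc2ncncc2cc1OCc1cccc(F)c1`, at 7400 nM. Compound 1 thus stands at the limit of > 10000 nM in this assay, at which 2 of the 3 values shown sit, with no number of its own.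

Compound 4 `O=C(Nc1cc2ncncc2cc1OCc1ccccc1Cl)Nc1cccc2ccccc12` keeps the core of compound 1 and changes only the group on the amide-type nitrogen, with naphthalen-1-yl in place of 3-chlorophenyl on an amide-type nitrogen. Going by the values given here, the only measured step between compounds differing in one place is a step that the two limits leave unreadable from compound 1 to compound 3. Among the compounds with values here, that step does not touch the amide-type nitrogen and has no readable size, so no measured step bears directly on this change, and the data favour neither direction. Within the data shown here, compound 2, at 7400 nM, shows only that a true number can appear. No shift beyond the usual scatter is therefore expected in this assay, and a further limit is the likeliest result. The expected change is a number no higher from compound 1 to compound 4 (the limit leaves the size open). For compound 4 the estimated value is 10000 nM, with an expected range from 4500 nM to 22000 nM.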

Compound 4, half-maximal inhibitory concentration: 2300 nM
The estimate for compound 4 lay 4.3-fold (0.64 log units) above the measured number; measured number below the stated range.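

For the compounds shown here, putting naphthalen-1-yl in place of 3-chlorophenyl on an amide-type nitrogen gives, in this assay, an at least 4.3-fold lower number from compound 1 to compound 4 (0.63 log units; beyond the scatter), and this is the only step with a readable size, as the earlier step on the saturated chain carbon cannot be read. It shows that the group on this nitrogen can move the read-out off the limit towards stronger inhibition, with the chlorine gone and a second six-membered aromatic ring of carbon in its place. The true size of the step may be larger than the printed figure, because compound 1 has no number of its own and only a limit marks its end of the comparison: the limit of > 10000 nM in this assay, at which 2 of the 4 values shown sit.

The compounds shown leave open whether the shift follows the added ring or the lost chlorine, as compound 4 differs from compound 1 in both at once, and a plain phenyl or a naphthalen-2-yl on the same nitrogen would begin to separate the two. They also leave open whether the same swap would act alike with 3-chlorophenyl rather than 2-chlorophenyl on the saturated chain carbon bound to the oxygen.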